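Ring size on the ether-bearing carbon: toward cyclopentyl

The source may hold more compounds than are shown below. What is called first, only, known or untested is meant among the compounds shown, and "the series" means these compounds.

Measured so far in a functional assay on cells for antagonist activity at Glucagon receptor (Homo sapiens), read by cAMP accumulation, in the presence of a further agent that is not named here; on this read-out lower numbers stand for stronger inhibition and higher numbers for weaker inhibition:
- compound 1 `O=C(O)CCNC(=O)c1ccc(C(Oc2ccc(-n3cc(C(F)(F)F)cn3)cc2)C2CC2)cc1`: 15000 nM
- compound 2 `O=C(O)CCNC(=O)c1ccc(C(Oc2ccc(-n3cc(C(F)(F)F)cn3)cc2)C2CCC2)cc1`: 3000 nM
- compound 3 `CCC(Oc1ccc(-n2cc(C(F)(F)F)cn2)cc1)c1ccc(C(=O)NCCC(=O)O)cc1`: > 22000 nM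

Compound 3 sits at a limit of this assay, not at a number (the limit of > 22000 nM in this assay, at which 1 of the 3 values shown sits). Compound 4 `O=C(O)CCNC(=O)c1ccc(C(Oc2ccc(-n3cc(C(F)(F)F)cn3)cc2)C2CCCC2)cc1` carries the change (cyclopentyl in place of ethyl on a saturated chain carbon bound to an aromatic carbon and an oxygen on an aromatic ring). Among the measured compounds shown here, two measured steps bear on it: an at least 7.3-fold higher number from compound 2 to compound 3 (0.86 log units; beyond the scatter) and a 5.0-fold lower number from compound 1 to compound 2 (0.70 log units; beyond the scatter), both beyond the scatter and both pointing the same way, the larger carbocycle giving the lower number. The small step of an at least 1.4-fold higher number from compound 1 to compound 3 (0.16 log units; that floor lies within the scatter) lies within the scatter. Cyclopentyl continues the same direction of growth, so a large lowering is expected, an at least 14-fold lower number from compound 3 to compound 4 (1.16 log units; beyond the scatter). Compound 4 is therefore estimated at 1500 nM, in the range 300 nM to 8000 nM.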

Compound 4, antagonist equilibrium constant: 4000 nM
Beside the measured number, compound 4's estimate is 2.7-fold (0.43 log units) below it; the range from low to high includes it.
By their numbers in this assay, from the lowest: compounds 2 and 4 (each within the scatter of the next); then compound 1. At a limit, above all of these: compound 3.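

In this assay, the lowering seen from cyclopropyl to cyclobutyl does not carry on to cyclopentyl: the step is a 1.3-fold higher number from compound 2 to compound 4 (0.12 log units; within the scatter), which leaves these two rings level. Cyclopentyl still stands apart from the smaller groups, with a 3.8-fold lower number from compound 1 to compound 4 (0.57 log units; beyond the scatter) and an at least 5.5-fold lower number from compound 3 to compound 4 (0.74 log units; beyond the scatter). The value of compound 3 in that last step is a limit of the assay, not a number: the limit of > 22000 nM in this assay, at which 1 of the 4 values shown sits.

Still open, going by these compounds, is whether cyclohexyl or tetrahydropyranyl at this position would hold the number at this level or move it. The compounds shown also leave open whether any such gain would survive a change to the carboxylic acid chain.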